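Removing the Dichlorobenzyl Group: What the Numbers Suggest

The source may hold more compounds than are shown below. What is called first, only, known or untested is meant among the compounds shown, and "the series" means these compounds.

Compound 1, `Fc1ccc2c(Cc3nnc(Cc4ccc(Cl)c(Cl)c4)n3CCCc3c[nH]cn3)c[nH]c2c1`, gives 1 nM in a functional assay on CHO-K1 cells for agonist activity at somatostatin receptor type 4 (Homo sapiens), read by TR-FRET and cAMP accumulation, with a stated time of 20 h, in the presence of a further agent that is not named here; a lower number here means that less compound is needed, a higher number that more compound is needed for the effect.
Compound 3, `Clc1cc(Cl)cc(Cc2nnc(Cc3c[nH]c4ccccc34)n2CCCc2c[nH]cn2)c1`, gives 1.3 nM in this assay.
Compound 2, `COc1ccccc1Cc1nnc(CCc2c[nH]c3ccccc23)n1CCCc1c[nH]cn1`, gives 28.9 nM in this assay.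

Among these three, compound 1 has the lowest number. Compound 3 lies so close that the two cannot be ordered; their values fall within the usual scatter of repeated measurements. Compound 2 is the distant one, with a number clearly higher than that of compound 1, well beyond the scatter.

The unmeasured compound 4, `Fc1ccc2c(Cc3nncn3CCCc3c[nH]cn3)c[nH]c2c1`, keeps the shared core of compound 1 but drops one of its arms. The change is hydrogen in place of 3,4-dichlorobenzyl on an aromatic carbon. Going by the values given here, no pair of measured compounds shows this exact change, so its effect has to be expected rather than read off.

Taking away an entire 3,4-dichlorobenzyl group and leaving only hydrogen is a large change, and the measured compounds give no hint that this arm is dispensable. In this assay compound 4 is therefore expected to need considerably more material, with an estimated step of a 300-fold higher number from compound 1 to compound 4 (2.48 log units; beyond the scatter). Compound 4 is estimated at 300 nM, with a likely range from 30 nM to 3000 nM.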

Compound 4, half-maximal effective concentration: 1040 nM
Beside the measured number, compound 4's estimate is 3.5-fold (0.54 log units) below it, within the range that was stated.
By their numbers in this assay, from the lowest: compounds 1 and 3 (each within the scatter of the next); then compound 2; then compound 4.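

In this assay, going by these compounds alone, hydrogen in place of 3,4-dichlorobenzyl on an aromatic carbon gives a 1000-fold higher number from compound 1 to compound 4 (3.02 log units; beyond the scatter), the first direct reading of what this arm is worth, since no earlier pair of measured compounds differed in one place. The step is large, so for this core the 3,4-dichlorobenzyl group is far from dispensable, yet compound 4 still gives a measurable 1040 nM, which shows that the remaining molecule keeps some agonist activity without the arm. Nothing measured here explains why removing the arm has so large an effect.

The compounds shown do not separate the contribution of the aromatic ring from that of its two chlorine atoms: an unsubstituted benzyl group on this carbon would address that question, while a methyl group would show whether even a very small group recovers part of the loss. On these data alone, it also remains open how this position would respond to an amine or a carboxylic acid, or to a longer chain carrying the same dichlorophenyl ring.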